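The source may hold more compounds than are shown below. What is called first, only, known or untested is meant among the compounds shown, and "the series" means these compounds.

Three ribosides sharing one core have been measured in a functional assay on K562 cells (Homo sapiens) for antiproliferative activity, with a stated time of 72 h; a lower number here means a stronger inhibitor, a higher number a weaker inhibitor. Compound 1, `OC[C@H]1O[C@@H](n2cnc3c(NCc4ccccc4Br)ncnc32)[C@H](O)[C@@H]1O`, gives 10000 nM in this assay. Compound 2, `COc1ccccc1CNc1ncnc2c1ncn2[C@@H]1O[C@H](CO)[C@@H](O)[C@H]1O`, gives 89000 nM, and compound 3, `COc1ccc(CNc2ncnc3c2ncn3C2OC(CO)[C@@H](O)[C@H]2O)c(O)c1`, gives 80800 nM. For the measured compounds named here, compound 2 therefore holds the highest number of the three: the gap to compound 3 is within the scatter, while the single step of an 8.9-fold higher number from compound 1 to compound 2 (0.95 log units; beyond the scatter) is the only one beyond it.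

Compound 4, `OC[C@H]1O[C@@H](n2cnc3c(NCc4cc(O)cc(O)c4)ncnc32)[C@H](O)[C@@H]1O`, has not yet been measured. It differs from compound 2 by 3,5-dihydroxyphenyl in place of 2-methoxyphenyl on a saturated chain carbon bound to a nitrogen on an aromatic ring.

Going by the values given here, the only measured step bearing on this change is the one from compound 1 to compound 2, which swapped a bromo for a methoxy on an aromatic carbon and raised the number substantially. That step concerns a different exchange on the benzyl ring, so it gives no direct guide. Compound 3, which carries both a methoxy and a hydroxy on its ring, stands within the scatter of compound 2, suggesting that adding hydroxy groups to this ring does not move the number far. Compound 4 is therefore expected to stay near compound 2, with a step of a 1.4-fold lower number from compound 2 to compound 4 (0.14 log units; within the scatter) in this assay. The estimate for compound 4 is 65000 nM, within a range from 20000 nM to 180000 nM.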

Compound 4, half-maximal inhibitory concentration: > 166000 nM
Compound 4 ended at the assay's limit; the forecaster's own chance of this, stated with the estimate: 15%; at least 2.5-fold (0.40 log units) between middle value and limit.
By their numbers in this assay, from the lowest: compound 1; then compounds 3 and 2 (each within the scatter of the next). At a limit, above all of these: compound 4.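

Compound 4 sits at a limit of the assay, and no other compound shown does: the limit of > 166000 nM in this assay, at which 1 of the 4 values shown sits. In this assay, replacing 2-methoxyphenyl with 3,5-dihydroxyphenyl on a saturated chain carbon bound to a nitrogen on an aromatic ring gives an at least 1.8-fold higher number from compound 2 to compound 4 (0.27 log units; that floor lies within the scatter), so the change brought no lower number, although the floor alone does not establish a real rise over compound 2. The comparison with the bromo compound is firmer, with an at least 16-fold higher number from compound 1 to compound 4 (1.22 log units; beyond the scatter), so this place now has two exchanges away from 2-bromophenyl, to 2-methoxyphenyl and to 3,5-dihydroxyphenyl, that both end beyond the scatter on the weaker side.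

How far the true number of compound 4 lies past its limit remains unknown, and the two hydroxy groups entered together, so the compounds shown do not separate what each contributes. Nor do they show whether 2-chlorophenyl would stay close to compound 1, or whether an amine or a carboxylic acid on this ring, or a longer chain leading to it, would shift the number in either direction.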